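The source may report more compounds than this note shows. Statements on the series, on what has been measured and on what is new or still open speak of the compounds shown alone.

Measured compounds in a functional assay on CHO-K1 cells for antagonist activity at melanin-concentrating hormone receptor 1 (Homo sapiens), read by inositol phosphate accumulation, with stated times of 10 min and 45 min; a lower number here means a stronger inhibitor, a higher number a weaker inhibitor:
compound 1 `Cc1nc(N2CCC(NS(=O)(=O)N(C)C)CC2)nc2ccc(NC(=O)/C=C/c3ccc(OC(F)(F)F)cc3)cc12` gives 31 nM
compound 2 `Cc1nc(N2CCC(N3CCNC3=O)CC2)nc2ccc(NC(=O)/C=C/c3ccc(OC(F)(F)F)cc3)cc12` gives 31 nM
compound 3 `Cc1nc(N2CCC(N3CCCS3(=O)=O)CC2)nc2ccc(NC(=O)/C=C/c3ccc(OC(F)(F)F)cc3)cc12` gives 16 nM

Compound 3 stands at the lowest of the three numbers, but its steps to the other two are both within the scatter: a 1.9-fold lower number from compound 1 to compound 3 (0.29 log units; within the scatter) and a 1.9-fold lower number from compound 2 to compound 3 (0.29 log units; within the scatter). The three substituents on the saturated ring carbon therefore cannot be ordered on these data, and no change at the digits printed from compound 1 to compound 2 (within the scatter) confirms that the acyclic and cyclic variants sit together.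

Compound 4 `Cc1nc(N2CCC(N3CCCC3=O)CC2)nc2ccc(NC(=O)/C=C/c3ccc(OC(F)(F)F)cc3)cc12` carries the next variation at the same position: a group of 6 heavy atoms (4 carbon, 1 nitrogen, 1 oxygen; one five-membered non-aromatic ring with 1 hetero atom) in place of a group of 7 heavy atoms (3 carbon, 1 nitrogen, 2 oxygen, 1 sulfur; one five-membered non-aromatic ring with 2 hetero atoms), on a saturated ring carbon. For the measured compounds named here, the step that bears most directly on it is the one between compound 2 and compound 3, since both sides of that comparison are five-membered rings on the saturated ring carbon and the change from compound 3 to compound 4 again swaps one such ring for another; that step was small, a 1.9-fold lower number from compound 2 to compound 3 (0.29 log units; within the scatter). The steps from compound 1 were likewise small. Going by the values given here, nothing among the measured compounds indicates that a ring of this kind at this position shifts this assay beyond the scatter, so for compound 4 the expected step is a 1.6-fold higher number from compound 3 to compound 4 (0.19 log units; within the scatter), a number in the range of compounds 1 to 3. Compound 4 is estimated at 25 nM, with a range of 10 nM to 60 nM.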

Compound 4, half-maximal inhibitory concentration: 12 nM
Beside the measured number, compound 4's estimate is 2.1-fold (0.32 log units) above it; the range from low to high includes it.
By their numbers in this assay, from the lowest: compounds 4, 3, 1 and 2 (each within the scatter of the next, the first and the last beyond it).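

In this assay, for the compounds shown here, the 2-oxopyrrolidin-1-yl group on the saturated ring carbon gives the first steps at this position that leave the scatter, both modest: one against the 2-oxoimidazolidin-1-yl group (a 2.6-fold lower number from compound 2 to compound 4 (0.41 log units; beyond the scatter)) and one against the open (dimethylsulfamoyl)amino group (a 2.6-fold lower number from compound 1 to compound 4 (0.41 log units; beyond the scatter)). The five-membered sulfur-containing ring of compound 3 stays within the scatter of compound 4 (a 1.3-fold lower number from compound 3 to compound 4 (0.12 log units; within the scatter)), so these two cannot be ordered, and the series now shows a separation only between its end members, with compound 3 overlapping all the others. No measured property is available to account for these steps.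

Open, going by these compounds, is whether the lower numbers depend on the five-membered ring at all: a six-membered 2-oxopiperidin-1-yl ring or an open-chain acetylamino group on the same carbon would separate ring size from the carbonyl itself. Equally open, on these data alone, is how far this position tolerates a change of a different kind, such as a dimethylamino group or a carboxylic acid in place of these neutral groups, since all four compounds carry no net charge here.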